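A few compounds are considered here, and "the series" means these few. Any claim that something is new, unique, unknown or untested is made for them only; others in the source may bear on it.

Compound 1 `COc1ccc(C2=C(c3cc(OC)c(OC)c(OC)c3)C(=O)CC2O[SiH2]C(C)(C)C)cc1OC` has been measured in an ADME assay on L132 cells (Homo sapiens) for cytotoxicity, read by MTT assay, with a stated time of 72 h; on this read-out higher numbers stand for weaker inhibition and lower numbers for stronger inhibition. In this assay compound 1 gives only a limit, > 100 ug/mL. That is the limit of > 100 ug/mL in this assay, at which 2 of the 3 values shown sit. Compound 3 `COc1ccc(C2=C(c3cc(OC)c(OC)c(OC)c3)CC(O)C2=O)cc1[N+](=O)[O-]` likewise gives only a limit in this assay, > 100 ug/mL. Among the measured compounds shown here, compound 2 `COc1ccc(C2=C(c3cc(OC)c(OC)c(OC)c3)C(=O)C(O[SiH2]C(C)(C)C)C2)cc1OC(C)C` gives 7 ug/mL in this assay, the single number among the three. Compound 1 therefore stands at the limit and cannot be placed any further on the numbers shown. Compound 4 `COC(=O)c1cc(C2=C(c3cc(OC)c(OC)c(OC)c3)C(=O)CC2O[SiH2]C(C)(C)C)ccc1OC` has not yet been measured in this assay. It differs from compound 1 in one place: methoxycarbonyl in place of methoxy on an aromatic carbon. The change sits ortho to a methoxy group and meta to a large group; cut one bond further out it reads 3,4-dimethoxyphenyl to 4-methoxy-3-(methoxycarbonyl)phenyl. For the measured compounds named here, no measured pair shows how such a change moves this assay, and compound 1 sits at the limit, so the step is expected to stay within the scatter, a number no higher from compound 1 to compound 4 (the limit leaves the size open), with no clear direction. Compound 4 is thus expected to give about 100 ug/mL in this assay, between 30 ug/mL and 300 ug/mL, and may well again be reported only as a limit.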

Compound 4, half-maximal inhibitory concentration: > 100 ug/mL
Compound 4: only a limit was reported; the forecaster's own chance of this, stated with the estimate: 60%; the middle value sits exactly at the limit.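

Among the compounds shown here, compound 1 and compound 4 each give only a limit in this assay, so no step between them can be read. The compounds shown leave open how far, and in which direction, methoxycarbonyl in place of methoxy on an aromatic carbon moves the half-maximal inhibitory concentration.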